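This account rests on a few compounds, and the source may have more. Where it says the series, first, only, none or still open, it means among the compounds named here.

Measured so far in an ADME assay on Vero cells (Chlorocebus sabaeus) for cytotoxicity, read by neutral red uptake, tested at 12.3 ug/mL; a lower number here means a stronger effect, a higher number a weaker effect of the compound at the concentration tested:
compound 1 `O=C1CSC(c2ccccc2Cl)N1CCN1CCCCC1` gives 100%
compound 2 `O=C1CSC(c2c(Cl)cccc2Cl)N1CCN1CCCCC1` gives 100%

Compound 1 stands level with compound 2; the step of no change at the digits printed from compound 1 to compound 2 (within the scatter) stays within the scatter. Compound 3 `Cc1ccc(C2SCC(=O)N2CCN2CCCCC2)cc1` is still to be measured in this assay. It differs from compound 1 by 4-methylphenyl in place of 2-chlorophenyl on a saturated ring carbon. Among the measured compounds shown here, the only measured step, no change at the digits printed from compound 1 to compound 2 (within the scatter), touches the same aromatic ring yet changes nothing, so no step argues for movement here. The expected step from compound 1 to compound 3 is no change at the digits printed from compound 1 to compound 3 (within the scatter), none beyond the scatter. Compound 3 is estimated at 100%, within 85% to 105%.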

Compound 3, a percentage reported as activity, at one concentration (the size of the read-out at that concentration, not a potency): 100%
Compound 3: middle estimate and measured number agree at the digits printed; the range from low to high includes it.
By their numbers in this assay, from the lowest: compounds 1, 2 and 3 (each within the scatter of the next).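

In this assay, replacing the whole aryl group, 2-chlorophenyl by 4-methylphenyl on the saturated ring carbon, gives no change at the digits printed from compound 1 to compound 3 (within the scatter). The earlier pair both carried chloro, whereas compound 3 has no chlorine, so at this position the read-out does not depend on a chloro group among the aryl groups shown. No measurement at hand gives a reason for this flat result.

As far as these compounds go, whether an amine or a carboxylic acid on the aromatic ring would shift the read-out remains open. With all three compounds level, nothing yet shows which changes at this position could move it.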